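Selenium in place of sulfur on the core of compound 1

The compounds below may be only part of what the source reports. "The series", "measured", "known", "first", "only" and "open" are said of these compounds alone.

Going by the values given here, compound 1 `CS/C(=N\C(=O)c1sccc1Cl)NC(=O)c1sccc1Cl` gives 24700 nM in a functional assay on PC-3 cells (Homo sapiens) for cytotoxicity, read by MTT assay, with a stated time of 72 h (on this read-out higher numbers stand for weaker inhibition of growth and lower numbers for stronger inhibition of growth), the highest of the two numbers known so far. Among the compounds with values here, compound 2 `C[Se]/C(=N\C(=O)c1cnc2ccccc2c1)NC(=O)c1cnc2ccccc2c1` gives 2330 nM in this assay, a lower number beyond the scatter; as compound 2 differs from compound 1 in two places, its value shows only that the selenium-bearing compound is the stronger of the pair. Compound 3 `C[Se]/C(=N\C(=O)c1sccc1Cl)NC(=O)c1sccc1Cl` carries the change (a group of 2 heavy atoms (1 carbon, 1 selenium; no ring) in place of a group of 2 heavy atoms (1 carbon, 1 sulfur; no ring), on a carbon with a double bond to nitrogen). Within the data shown here, no measured step of this kind exists. A moderate lowering is expected, with the estimated step of a 2.1-fold lower number from compound 1 to compound 3 (0.31 log units; beyond the scatter). Compound 3 is expected to give 12000 nM, within 4000 nM to 30000 nM.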

Compound 3, concentration for 50% growth inhibition: 970 nM
Compound 3: the middle estimate sits 12-fold (1.09 log units) above what was measured; measured number below the stated range.
By their numbers in this assay, from the lowest: compound 3; then compound 2; then compound 1.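

With everything else on the core of compound 1 held fixed, replacing methylsulfanyl with its selenium counterpart on a carbon with a double bond to nitrogen gives a 25-fold lower number from compound 1 to compound 3 (1.41 log units; beyond the scatter) in this assay. This pair isolates the exchange at this position, which compounds 1 and 2, differing in two places, could not do. No measurement here accounts for the size of this step.

Going by these compounds, it remains open whether the exchange gives a similar step with the other groups of compound 2. On these data alone, how a longer chain on selenium, such as ethyl, or an amine at this carbon would read is also open.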